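A Bare Phenyl Amide on the Shared Core

A few compounds are considered here, and "the series" means these few. Any claim that something is new, unique, unknown or untested is made for them only; others in the source may bear on it.

In a functional assay on AN3-CA cells (Homo sapiens) for antiproliferative activity, read by MTT assay, with a stated time of 72 h (a higher number here means a weaker inhibitor, a lower number a stronger inhibitor), compound 1 `O=C(Nc1ccc(Cl)c(-c2nnc3c(Cl)cccn23)c1)c1ccc(F)cc1Cl` gives only the assay's limit of > 100000 nM. Compound 2 `O=C(Nc1ccc(Cl)c(-c2nnc3c(Cl)cccn23)c1)c1ccon1` in this assay likewise reaches only the limit of > 100000 nM. For the measured compounds named here, the one measured step, a step that the two limits leave unreadable from compound 1 to compound 2, therefore cannot be sized. Compound 3 `O=C(Nc1ccc(Cl)c(-c2nnc3c(Cl)cccn23)c1)c1ccccc1` differs from compound 1 by phenyl in place of 2-chloro-4-fluorophenyl on a carbonyl carbon. Going by the values given here, with both measured values sitting at the limit of > 100000 nM in this assay, at which 2 of the 2 values shown sit, no step offers a direction for this change, and no movement beyond the scatter is expected. The expected step is a step that the limit leaves unreadable from compound 1 to compound 3. Compound 3 is estimated at 150000 nM, with a range from 50000 nM to 500000 nM.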

Compound 3, half-maximal inhibitory concentration: 67600 nM
Beside the measured number, compound 3's estimate is 2.2-fold (0.35 log units) above it; low and high end bracket the measured number.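

Compound 3, with phenyl on the carbonyl carbon, gives the first readable number at this place, while the other two compounds stay at a limit: the limit of > 100000 nM in this assay, at which 2 of the 3 values shown sit.

Phenyl in place of 2-chloro-4-fluorophenyl gives an at least 1.4-fold lower number from compound 1 to compound 3 (0.17 log units; that floor lies within the scatter), and phenyl in place of 1,2-oxazol-3-yl gives an at least 1.4-fold lower number from compound 2 to compound 3 (0.17 log units; that floor lies within the scatter). Neither step is shown to go beyond the scatter, so no gain can be claimed for phenyl over either group.

Going by these compounds, it remains open how a single-halogen group such as 2-chlorophenyl or 4-fluorophenyl would read. On these data alone, it is also open whether an amine or a carboxylic acid on the phenyl would move the number beyond the scatter.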